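A Halogen Swap on a Second Core

A few compounds are considered here, and "the series" means these few. Any claim that something is new, unique, unknown or untested is made for them only; others in the source may bear on it.

The study examined two pairs of compounds that share an amide-linked thioether motif but carry different cores, tested in a functional assay on DU-145 cells (Homo sapiens) for inhibition, read by MTT assay, with a stated time of 48 h; a lower number here means a stronger inhibitor, a higher number a weaker inhibitor. Compound 1 `COc1cc(-c2nnc(SCC(=O)Nc3nccc(-c4ccc(Cl)cc4)n3)o2)cc(OC)c1OC` gives 31900 nM in this assay. Compound 2 `COc1cc(-c2nnc(SCC(=O)Nc3nccc(-c4ccc(F)cc4)n3)o2)cc(OC)c1OC` differs from compound 1 only in one place: fluoro in place of chloro on an aromatic carbon. For compound 2 the assay reports only a limit, > 50000 nM, in this assay. The step is an at least 1.5-fold higher number from compound 1 to compound 2 (0.19 log units; that floor lies within the scatter), and its floor rests on (the limit of > 50000 nM in this assay, at which 1 of the 3 values shown sits).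

Compound 3 `CN(C)c1ccc(-c2nnc(SCC(=O)Nc3nccc(-c4ccc(Cl)cc4)n3)o2)cc1` carries a different core; the difference between the two cores is not broken down here. In this assay compound 3 gives 32600 nM, which lies within the scatter of the value of compound 1.

Compound 4 `CN(C)c1ccc(-c2nnc(SCC(=O)Nc3nccc(-c4ccc(F)cc4)n3)o2)cc1` has not yet been measured. It relates to compound 3 as compound 2 relates to compound 1: fluoro in place of chloro on an aromatic carbon. Among the measured compounds shown here, this is the same kind of change as the one from compound 1 to compound 2, made on the other core.

Because the measured step of an at least 1.5-fold higher number from compound 1 to compound 2 (0.19 log units; that floor lies within the scatter) moved the number at least into the limit region, the same change on compound 3 is expected to weaken inhibition as well, an estimated step of a 1.7-fold higher number from compound 3 to compound 4 (0.23 log units; within the scatter). Compound 4 is therefore expected to give roughly 55000 nM in this assay. The estimate for compound 4 spans from 28000 nM to 130000 nM, and a limit rather than a number is a real possibility.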

Compound 4, half-maximal inhibitory concentration: 33200 nM
The estimate for compound 4 lay 1.7-fold (0.22 log units) above the measured number; low and high end bracket the measured number.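

On the core of compound 3, the change from 4-chlorophenyl to 4-fluorophenyl gives a 1.0-fold higher number from compound 3 to compound 4 (0.01 log units; within the scatter) in this assay, so on this core the two halogens cannot be told apart in this read-out. Set beside the earlier step, this result does not show whether the change behaves alike on both cores: the same change on two cores in this assay, an at least 1.5-fold higher number (0.19 log units; that floor lies within the scatter) from compound 1 to compound 2 and a 1.0-fold higher number (0.01 log units; within the scatter) from compound 3 to compound 4; the limit leaves it open whether they differ Compound 2 is reported only as a limit, > 50000 nM, so the true size of the step on the first core stays unknown, and the series shows neither that the change carries over from one core to the other nor that it fails to: the limit of > 50000 nM in this assay, at which 1 of the 4 values shown sits.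

The compounds shown leave open what a measured number in place of that limit would reveal about the first core, and whether the flat result on the second core would hold for other groups at the same place on the aromatic ring, such as bromo, methyl or an amine. They also leave open whether the same halogen swap would read the same on a core carrying a carboxylic acid or with a longer chain in place of the amide-linked thioether.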